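The compounds below may be only part of what the source reports. "The series", "measured", "known", "first", "only" and "open" are said of these compounds alone.

Measured so far: compound 1 `COc1cc(C)cc(-c2c(-c3ccnc(-c4ccc(C(C)=O)cc4)c3)cnn2CC#N)c1` with 21%, compound 2 `COc1cc(C)cc(-c2nn(CC#N)cc2-c2ccc(-c3cccc(C(C)=O)c3)nc2)c1` with 24%, compound 3 `COc1cc(C)cc(-c2nn(CC#N)cc2-c2ccnc(-c3ccc(N(C)C)cc3)c2)c1` with 2%, all in a functional assay on ACHN cells (Homo sapiens) for cytotoxicity, read by sulforhodamine B assay, with a stated time of 48 h, tested at 1 uM; on this read-out lower numbers stand for a stronger effect and higher numbers for a weaker effect at the one concentration tested.

Among these three numbers compound 1 stands second highest. Its nearest neighbour is compound 2, whose number lies within the scatter of that of compound 1; the furthest is compound 3, whose number lies lower, beyond the scatter. Compound 3 carries a dimethylamino group and shows the lowest number of the three.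

Compound 4 `COc1cc(C)cc(-c2c(-c3ccnc(-c4ccc(N(C)C)cc4)c3)cnn2CC#N)c1` has not been measured. Against compound 1 it differs by dimethylamino in place of acetyl on an aromatic carbon.

Among the measured compounds shown here, no step between measured compounds is known for this change. For the measured compounds named here, since compound 3, the one dimethylamino-bearing compound, gives 2%, the expected step from compound 1 to compound 4 is a fall in this assay beyond the scatter, about a number 13 percentage points lower from compound 1 to compound 4 (beyond the scatter). Compound 4 is estimated at 8%, with a range from 0% to 25%.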

Compound 4, a percentage reported as activity, at one concentration (the size of the read-out at that concentration, not a potency): 19%
Compound 4: middle estimate off by 11 percentage points, on the low side; the measured number falls inside the stated range.
By their numbers in this assay, from the lowest: compound 3; then compounds 4, 1 and 2 (each within the scatter of the next).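

In this assay, 4-(dimethylamino)phenyl in place of 4-acetylphenyl gives a number 2 percentage points lower from compound 1 to compound 4 (within the scatter), so the two groups cannot be told apart at this position on this core. The dimethylamino group alone therefore does not go with a number as low as that of compound 3 at 2%. No evidence bearing on this result is available. Open, from the compounds shown here alone, is whether a morpholine or a carboxylic acid on this aromatic carbon would move the number. Also open, going by these compounds, is which other feature of compound 3 goes with its value.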